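This account rests on a few compounds, and the source may have more. Where it says the series, first, only, none or still open, it means among the compounds named here.

Measured so far:
- compound 1 `CN1CCN(CCCS(=O)(=O)c2ccc3nc(NC(=O)NC(=O)c4cccc(-n5cccn5)c4Cl)sc3c2)CC1`: 12 nM
- compound 2 `Cc1cc(C)n(-c2ccc(Cl)c(C(=O)NC(=O)Nc3nc4ccc(S(=O)(=O)CCCN5CCN(C)CC5)cc4s3)c2)n1`: 78 nM

In an ADME assay on the whole organism (strain Han-Wistar) for pharmacokinetics, with Rattus norvegicus as the target, read by LC-MS, at a dose of 2 mg/kg by the oral route (on this read-out lower numbers stand for lower exposure and higher numbers for higher exposure at the dose given), compound 2 gives the higher of the two numbers; compound 1 gives the lower. Compound 3 `CN1CCN(CCCS(=O)(=O)c2ccc3nc(NC(=O)NC(=O)c4cc(C5CC5)ccc4Cl)sc3c2)CC1` is not yet measured. It is reached from compound 2 by a single change: cyclopropyl in place of 3,5-dimethyl-1H-pyrazol-1-yl on an aromatic carbon. Compound 1 and compound 2 differ in more than one place, so nothing about the effect of this one change can be read from them; the two values show only how far apart two members of this series can lie. Among the compounds with values here, with no measured step to lean on, a step of modest size is expected from compound 2 to compound 3, not clearly beyond the scatter, in either direction. Compound 3 is therefore expected to give about 50 nM in this assay, with a plausible range from 12 nM to 200 nM, a step of a 1.6-fold lower number from compound 2 to compound 3 (0.19 log units; within the scatter).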

Compound 3, maximal plasma concentration: 1400 nM
Beside the measured number, compound 3's estimate is 28-fold (1.45 log units) below it; the whole stated range lies below it.
By their numbers in this assay, from the lowest: compound 1; then compound 2; then compound 3.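

In this assay, putting cyclopropyl in place of 3,5-dimethyl-1H-pyrazol-1-yl on this aromatic carbon gives an 18-fold higher number from compound 2 to compound 3 (1.25 log units; beyond the scatter), which shows that this single position can strongly shift the number. Replacing the whole 2-chloro-3-(1H-pyrazol-1-yl)phenyl group on the carbonyl carbon with 2-chloro-5-cyclopropylphenyl gives a 120-fold higher number from compound 1 to compound 3 (2.07 log units; beyond the scatter), also a large step, although these two groups differ both in what they carry and in where they carry it. No measurement at hand bears on what lies behind these steps.

The change from compound 2 to compound 3 removes heavy atoms and hydrogen-bond acceptors together, and the compounds shown cannot separate the two. From the compounds shown here alone, it also remains open whether a methyl, an isopropyl or a phenyl group on this carbon would give a number like that of compound 3.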